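The source may hold more compounds than are shown below. What is called first, only, known or untested is meant among the compounds shown, and "the series" means these compounds.

Measured compounds:
compound 1, `CCOC(=O)C[C@H]1CN(C)CC[C@@H]1c1ccc(Cl)cc1`, 79 nM
compound 2, `CN1CC[C@H](c2ccc(Cl)cc2)[C@@H](CCC(=O)Nc2ccccc2)C1`, 201 nM

Both were tested in an assay on striatum with sodium-dependent dopamine transporter (Rattus norvegicus) as the target; a higher number here means a weaker inhibitor, a lower number a stronger inhibitor. Compound 1 gives the lower of the two numbers, and the gap between compound 1 and compound 2 lies beyond the usual scatter of repeated measurements, so compound 1 stands as the stronger inhibitor of the pair. The two differ in the chain carried on the shared core, and no single-step comparison between them is available, so only their two values can be set side by side.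

Compound 3, `CN1CC[C@H](c2ccc(Cl)cc2)[C@@H](CCCO)C1`, has not yet been measured. It is derived from compound 1 by one change: 2-hydroxyethyl in place of ethoxycarbonyl on a saturated chain carbon bound to a saturated ring carbon. The ester of compound 1 is thus replaced by a shorter chain ending in a hydroxyl, keeping the core untouched.

Going by the values given here, with only two values and no measured step to lean on, the expectation for compound 3 rests on the pattern that compound 1, bearing the ester, gives 79 nM. The expected change is estimated as a 1.9-fold higher number from compound 1 to compound 3 (0.28 log units; within the scatter), a modest move toward a weaker inhibitor. Compound 3 is estimated at 150 nM, in the range 50 nM to 500 nM.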

Compound 3, inhibition constant: 16 nM
The estimate for compound 3 lay 9.4-fold (0.97 log units) above the measured number, outside the stated range (below it).
By their numbers in this assay, from the lowest: compound 3; then compound 1; then compound 2.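

In this assay, replacing ethoxycarbonyl with 2-hydroxyethyl on a saturated chain carbon bound to a saturated ring carbon gives a 4.9-fold lower number from compound 1 to compound 3 (0.69 log units; beyond the scatter), which shows that the ester is not required at this position for a low number and that a chain ending in a hydroxyl can take its place without loss. Read one bond further out, the same difference is (ethoxycarbonyl)methyl to 3-hydroxypropyl, and it changes several things at once: the entering group has fewer heavy atoms, loses the double bond of the leaving group and carries a hydrogen-bond donor that ethoxycarbonyl lacks, so this single step cannot assign the lower number to any one of these differences. Nothing available here accounts for the size of the step.

The compounds shown leave open whether the hydroxyl itself matters, since no chain of the same length ending in a methyl ether, an amine or a carboxylic acid stands beside compound 3. They also leave open how the number would respond to a shorter chain, or to a longer one such as 4-hydroxybutyl, at this position.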